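Moving the Pyridine Nitrogen in a Topoisomerase Inhibitor Series

The source may report more compounds than this note shows. Statements on the series, on what has been measured and on what is new or still open speak of the compounds shown alone.

Of the compounds shown here, three built on one shared core have been tested in an assay on isolated protein for inhibition of DNA topoisomerase 1 (Homo sapiens), with a stated time of 30 min, tested at 100 uM; a higher number here means a stronger effect of the compound at the concentration tested, a lower number a weaker effect. Compound 1 `Oc1ccc(-c2cc(-c3ccncc3)nc(-c3ccc(Cl)cc3)c2)cc1` gives 5.9%. Compound 2 `Oc1cccc(-c2cc(-c3ccc(Cl)cc3)nc(-c3cccnc3)c2)c1` gives 2.8%. Compound 3 `Oc1ccc(-c2cc(-c3ccc(Cl)cc3)nc(-c3ccccn3)c2)cc1` gives 12.7%; its number differs from those of compound 1 and compound 2 only within the scatter, so none of the three can be set apart from the others. Going by the values given here, the only single-place step available, a number 6.8 percentage points higher from compound 1 to compound 3 (within the scatter), exchanges one pyridyl group for another of the same size and shows no effect beyond the scatter.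

Compound 4 `Oc1ccc(-c2cc(-c3ccc(Cl)cc3)nc(-c3cccnc3)c2)cc1` is not yet measured. It differs from compound 3 in pyridin-3-yl in place of pyridin-2-yl on an aromatic carbon. This is again an exchange of one pyridyl group for another, the same kind of change as between compound 1 and compound 3, where the step stayed within the scatter. Compound 2 also carries a pyridin-3-yl group but differs from compound 4 in a second place as well, so it offers no clean comparison. The step from compound 3 to compound 4 is therefore expected to be a number 5.7 percentage points lower from compound 3 to compound 4 (within the scatter), nothing beyond the scatter. Compound 4 is estimated at 7%, within a range from 0% to 18%.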

Compound 4, a percentage reported as inhibition, at one concentration (the size of the read-out at that concentration, not a potency): 18.8%
Beside the measured number, compound 4's estimate is 11.8 percentage points below it; the whole stated range lies below it.
By their numbers in this assay, from the lowest: compounds 2, 1, 3 and 4 (each within the scatter of the next, the first and the last beyond it).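

In this assay, swapping one pyridyl group for another at this place can now matter: pyridin-3-yl in place of pyridin-4-yl gives a number 12.9 percentage points higher from compound 1 to compound 4 (beyond the scatter) and is the only such exchange shown that passes the scatter, while pyridin-3-yl in place of pyridin-2-yl gives a number 6.1 percentage points higher from compound 3 to compound 4 (within the scatter) and does not. The pyridine is not the only part that counts, since with pyridin-3-yl held fixed, 4-hydroxyphenyl in place of 3-hydroxyphenyl gives a number 16 percentage points higher from compound 2 to compound 4 (beyond the scatter) and also passes the scatter. No supporting data accompany these numbers, so the reason for either step remains unknown.

From the compounds shown here alone, whether an amine or a carboxylic acid in place of the pyridyl group would raise or lower the number remains open. Going by these compounds, each number is a read-out at one concentration, so the potency of compound 4 also stays open.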